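A few compounds are considered here, and "the series" means these few. Any claim that something is new, unique, unknown or untested is made for them only; others in the source may bear on it.

In a functional assay for inhibition, with Homo sapiens as the target (a lower number here means a stronger inhibitor, a higher number a weaker inhibitor), three compounds share one core and differ in a single group on an aromatic carbon. Compound 1 `OCc1cc(-c2ccccc2)c2ccc(OCc3cccc(C4(O)CCOCC4)c3)cc2c1`, with hydroxymethyl, gives 9 nM. Compound 2 `CC(C)(O)c1cc(-c2ccccc2)c2ccc(OCc3cccc(C4(O)CCOCC4)c3)cc2c1`, with 1-hydroxy-1-methylethyl, gives 59 nM. Compound 3 `COC(C)c1cc(-c2ccccc2)c2ccc(OCc3cccc(C4(O)CCOCC4)c3)cc2c1`, with 1-methoxyethyl, gives 41 nM. Compound 3 therefore stands level with compound 2, the step being a 1.4-fold lower number from compound 2 to compound 3 (0.16 log units; within the scatter). Compound 1 is the strongest inhibitor of the three, as the other two steps show: a 6.6-fold higher number from compound 1 to compound 2 (0.82 log units; beyond the scatter) and a 4.6-fold higher number from compound 1 to compound 3 (0.66 log units; beyond the scatter).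

Compound 4 `N#Cc1cc(-c2ccccc2)c2ccc(OCc3cccc(C4(O)CCOCC4)c3)cc2c1` has not yet been measured. Its change is cyano in place of 1-methoxyethyl on an aromatic carbon. For the measured compounds named here, no measured step involves cyano, so the guide is indirect. Like compound 2 and compound 3, compound 4 lacks the hydroxymethyl of compound 1, so it is expected to stay nearer to those two. In this assay, the expected step is a 1.4-fold lower number from compound 3 to compound 4 (0.14 log units; within the scatter), which means no clear change beyond the scatter, though the uncertainty is wide. For compound 4 the estimated value is 30 nM, with an expected range from 9 nM to 100 nM.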

Compound 4, half-maximal inhibitory concentration: 3 nM
Compound 4: the middle estimate sits 10-fold (1.00 log units) above what was measured; measured number below the stated range.
By their numbers in this assay, from the lowest: compound 4; then compound 1; then compounds 3 and 2 (each within the scatter of the next).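

In this assay the hydroxymethyl of compound 1 proves not to be needed for a low number at this position, since cyano gives a 3.0-fold lower number from compound 1 to compound 4 (0.48 log units; beyond the scatter) and so sits beyond the scatter on the stronger side. The other two groups, both larger branched chains, fall much further behind, with a 14-fold lower number from compound 3 to compound 4 (1.14 log units; beyond the scatter) and a 20-fold lower number from compound 2 to compound 4 (1.29 log units; beyond the scatter). The first of those steps is the more telling one: 1-methoxyethyl and cyano have the same counts of hydrogen-bond donors and acceptors, so those counts alone do not separate the two compounds.

Nothing measured here explains why cyano does so well. On these data alone, it also stays open whether the gain belongs to the nitrile itself or to any compact group, which a chlorine, a methyl or an ethynyl at this carbon would help to settle.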